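The compounds below may be only part of what the source reports. "The series", "measured", "known", "first", "only" and "open" are said of these compounds alone.

Working notes on the series

Three compounds share a core and have been run in a functional assay on KB 3-1 cells (Homo sapiens) for inhibition, with a stated time of 72 h; a lower number here means a stronger inhibitor, a higher number a weaker inhibitor. Compound 1 `CC(=O)Oc1cc2oc(-c3ccccc3)cc(=O)c2c(O)c1OC(C)=O` gives 69300 nM. Compound 2 `CC(=O)Oc1cc2oc(-c3ccccc3)cc(=O)c2c(OC(C)=O)c1OC(C)=O`, which carries one more acetyl, gives 57200 nM; the change a 1.2-fold lower number from compound 1 to compound 2 (0.08 log units; within the scatter) is too small to read as a difference. Compound 3 `CC(=O)Oc1cc2oc(-c3ccccc3)cc(=O)c2c(OCc2ccccc2)c1OC(C)=O` gives 12200 nM, and its steps of a 5.7-fold lower number from compound 1 to compound 3 (0.75 log units; beyond the scatter) and a 4.7-fold lower number from compound 2 to compound 3 (0.67 log units; beyond the scatter) are both beyond the scatter, so compound 3 stands apart from the other two, which cannot be ordered against each other.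

Compound 4 `CC(=O)Oc1cc2oc(-c3ccccc3)cc(=O)c2c(O)c1OCc1ccccc1` has not yet been measured. It differs from compound 1 by benzyl in place of acetyl on an oxygen on an aromatic ring. The same change, benzyl in place of acetyl on an oxygen on an aromatic ring, has already been made once among the measured compounds: benzyl in place of acetyl on an oxygen on an aromatic ring gave a 4.7-fold lower number from compound 2 to compound 3 (0.67 log units; beyond the scatter). The two cores on which the change is made differ by hydrogen in place of acetyl on an oxygen on an aromatic ring, which is the pairing whose step a 1.2-fold lower number from compound 1 to compound 2 (0.08 log units; within the scatter) lies within the scatter. The place of the change is described in the same words in both cases, so it is taken as the same change rather than merely one of the same kind.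

On that basis the step from compound 1 to compound 4 is expected to be of about the size seen once already, namely a 4.6-fold lower number from compound 1 to compound 4 (0.66 log units; beyond the scatter), because compound 3 reached 12200 nM from compound 2 by this change. For the measured compounds named here, compound 4 is therefore estimated at 15000 nM, with a range of 5000 nM to 45000 nM allowing for the usual scatter and for only one prior instance of the change.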

Compound 4, half-maximal inhibitory concentration: 18300 nM
Compound 4: middle estimate off by 1.2-fold (0.09 log units), on the low side; the range from low to high includes it.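

In this assay, benzyl in place of acetyl on an oxygen on an aromatic ring gives a 3.8-fold lower number from compound 1 to compound 4 (0.58 log units; beyond the scatter), and this second instance of the change cannot be told apart from the first: the same change on two cores in this assay, a 4.7-fold lower number (0.67 log units; beyond the scatter) from compound 2 to compound 3 and a 3.8-fold lower number (0.58 log units; beyond the scatter) from compound 1 to compound 4, 1.2-fold (0.09 log units) apart, within the scatter of two such steps. On these two cores, which differ by hydrogen in place of acetyl on an oxygen on an aromatic ring, the change from acetoxy to benzyloxy therefore carries over in the same direction and at a similar size. This rests on only two instances, on closely related cores and in this assay alone, so it does not show that the step would hold on a core that differs in any other way, and it does not explain why the number falls.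

The compounds shown leave open whether another group on that oxygen, such as a longer alkyl chain, a chain ending in an amine or one ending in a carboxylic acid, would give a step of similar size. They also leave open whether the change would carry over to a core with a methyl ether in place of the remaining acetyl.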